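This account rests on a few compounds, and the source may have more. Where it says the series, first, only, none or still open, it means among the compounds named here.

Compound 2 `C=CCC(N)(CO)CCc1ccc(OCCCCCCC)cc1` gives the highest of the two numbers measured in a functional assay on the whole organism (spleen, spleen) with Rattus norvegicus as the target (a higher number here means that more compound is needed for the effect, a lower number that less compound is needed), namely 3.1 mg/kg. Its nearest neighbour is compound 1 `CCCCCCCOc1ccc(CCC(N)(CC)CO)cc1`, which in this assay gives 0.044 mg/kg; the step of a 70-fold higher number from compound 1 to compound 2 (1.85 log units; beyond the scatter) is large. Compound 3 `CCCCCCCOc1ccc(CC[C@](N)(CO)CCC)cc1` has not yet been measured. It differs from compound 2 by a group of 7 heavy atoms (5 carbon, 1 nitrogen, 1 oxygen; no ring) in place of a group of 7 heavy atoms (5 carbon, 1 nitrogen, 1 oxygen; no ring), on a saturated chain carbon, two bonds along the chain from an aromatic carbon. For the measured compounds named here, the only measured step that bears on this change is the one from compound 1 to compound 2, where a group without a double bond was exchanged for one with a double bond and the number rose steeply. Going by the values given here, compound 3 reverses that feature, its side group being saturated like that of compound 1, though with a single defined stereocentre whose effect no measured pair reveals. Compound 3 is therefore expected to move back toward compound 1, with a 10-fold lower number from compound 2 to compound 3 (1.01 log units; beyond the scatter) estimated as the step in this assay. Compound 3 is estimated at 0.3 mg/kg, within 0.03 mg/kg to 3 mg/kg.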

Compound 3, dose for 50% inhibition: > 10 mg/kg
Compound 3 gave a limit, no number; the forecaster's own chance of this, stated with the estimate: 5%; middle value at least 33-fold (1.52 log units) away from the limit.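

In this assay compound 3 gives > 10 mg/kg, which is a limit of the assay and not a number. With the 1-amino-1-(hydroxymethyl)butyl group on a saturated chain carbon, two bonds along the chain from an aromatic carbon, the result shows an at least 3.2-fold higher number from compound 2 to compound 3 (0.50 log units; beyond the scatter) and an at least 220-fold higher number from compound 1 to compound 3 (2.35 log units; beyond the scatter). A side group without a double bond therefore does not by itself bring the low number of compound 1, and compound 3 goes against any pattern in which the double bond of compound 2 alone sets the number high.

As far as these compounds go, the true size of both steps stays open, as compound 3 gives no number: the limit of > 10 mg/kg in this assay, at which 1 of the 3 values shown sits. Also open is how the mirror-image form of compound 3, or a methyl group in place of its side chain, would read in this assay.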